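A Trifluoromethyl Swap on the Benzyl Group

This account rests on a few compounds, and the source may have more. Where it says the series, first, only, none or still open, it means among the compounds named here.

In a functional assay (Platelet, plasma) for inhibition, with Homo sapiens as the target (on this read-out higher numbers stand for weaker inhibition and lower numbers for stronger inhibition), compound 1 `N#Cc1cc2c(nc1N1CCC(C(=O)NS(=O)(=O)Cc3ccccc3)CC1)CCCC2=O` gives 117000 nM. Compound 2 `CN1Cc2nc(N3CCC(C(=O)NS(=O)(=O)Cc4ccccc4)CC3)c(C#N)cc2C1=O` reads > 300000 nM, which is a limit of the assay and not a number. Compound 3 `N#Cc1cc2c(nc1N1CCC(C(=O)NS(=O)(=O)Cc3ccccc3F)CC1)COC2=O` gives 23700 nM, the lower of the two true numbers and clearly beyond the usual scatter from compound 1.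

Compound 4 `N#Cc1cc2c(nc1N1CCC(C(=O)NS(=O)(=O)Cc3ccc(C(F)(F)F)cc3)CC1)COC2=O` carries 4-(trifluoromethyl)phenyl in place of 2-fluorophenyl on a saturated chain carbon bound to a sulfonyl sulfur. For the measured compounds named here, no measured pair of compounds differs by this change alone, so any forecast is loose.

A modest 1.6-fold lower number from compound 3 to compound 4 (0.20 log units; within the scatter) is expected, toward a lower number and stronger inhibition. The estimate for compound 4 is 15000 nM, with an expected range from 4000 nM to 60000 nM.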

Compound 4, half-maximal inhibitory concentration: 15900 nM
Compound 4: middle estimate off by 1.1-fold (0.03 log units), on the low side; low and high end bracket the measured number.
By their numbers in this assay, from the lowest: compounds 4 and 3 (each within the scatter of the next); then compound 1. At a limit, above all of these: compound 2.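

In this assay, putting 4-(trifluoromethyl)phenyl in place of 2-fluorophenyl on the saturated chain carbon bound to a sulfonyl sulfur gives a 1.5-fold lower number from compound 3 to compound 4 (0.17 log units; within the scatter). This is the first step shown at this position, and it shows that a group of 10 heavy atoms and one of 7 cannot be told apart here. Nothing measured here explains this result. On these data alone, whether an amine or a carboxylic acid on this phenyl ring would shift the number remains open. So does whether 4-(trifluoromethyl)phenyl would behave the same way on the cores of compound 1 and compound 2.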